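Substance-P receptor binding: benzyl ring methylation in a piperazine urea series

The compounds below may be only part of what the source reports. "The series", "measured", "known", "first", "only" and "open" are said of these compounds alone.

Measured compounds in an assay on CHO cells for binding affinity to Substance-P receptor (Homo sapiens); a lower number here means a stronger inhibitor, a higher number a weaker inhibitor:
compound 1 `CCCCCN(CCCCC)C(=O)N1CCN(C(=O)N(c2ccccc2)c2ccccc2)[C@H](C(=O)NCCN(C(C)C)C(C)C)C1` gives 217 nM
compound 2 `CCCCCN(CCCCC)C(=O)N1CCN(C(=O)N(c2ccccc2)c2ccccc2)[C@H](C(=O)N(C)CCN(C)C)C1` gives 930 nM
compound 3 `CCCCCN(CCCCC)C(=O)N1CCN(C(=O)N(c2ccccc2)c2ccccc2)[C@H](C(=O)N(C)CCN(C)Cc2ccccc2)C1` gives 290 nM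

Compound 3 sits second highest of the three numbers in this assay, within the scatter of compound 1 and beyond it against compound 2. The next compound, compound 4 `CCCCCN(CCCCC)C(=O)N1CCN(C(=O)N(c2ccccc2)c2ccccc2)[C@H](C(=O)N(C)CCN(C)Cc2cc(C)cc(C)c2)C1`, carries 3,5-dimethylphenyl in place of phenyl on a saturated chain carbon bound to an amine nitrogen. Among the compounds with values here, no measured step exchanges one aryl for another; the nearest is a 3.2-fold lower number from compound 2 to compound 3 (0.51 log units; beyond the scatter), and the aminoethyl swap a 4.3-fold higher number from compound 1 to compound 2 (0.63 log units; beyond the scatter) touches a different part. Neither pair tells what two methyl groups on that ring do. For compound 4 a change no larger than the scatter is expected, a 1.3-fold lower number from compound 3 to compound 4 (0.10 log units; within the scatter), giving an estimate of 230 nM with a range of 80 nM to 650 nM in this assay.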

Compound 4, half-maximal inhibitory concentration: 200 nM
Estimate against measurement, compound 4: 1.2-fold (0.06 log units) above; the measured number falls inside the stated range.
By their numbers in this assay, from the lowest: compounds 4, 1 and 3 (each within the scatter of the next); then compound 2.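

In this assay, within the data shown here, the first aryl exchange at this place, on a saturated chain carbon bound to an amine nitrogen, is a 1.5-fold lower number from compound 3 to compound 4 (0.16 log units; within the scatter) and shows that two methyl groups on the benzyl ring leave the number within the scatter of the plain ring. Replacing hydrogen there with 3,5-dimethylphenyl gives a 4.7-fold lower number from compound 2 to compound 4 (0.67 log units; beyond the scatter) and keeps the number beyond the scatter of the unsubstituted chain end. Nothing available explains either step.

Open, from the compounds shown here alone, is whether a single methyl group, a chlorine or a methoxy on that ring would move the number beyond the scatter.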